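One Methyl Less: Estimating Compound 4 From Compound 1

The compounds below may be only part of what the source reports. "The series", "measured", "known", "first", "only" and "open" are said of these compounds alone.

Compound 1 `C[C@@H](O)[C@H]1C(=O)N2C(C(=O)OCOC(=O)C(C)(C)C)=C(S[C@@H]3CN[C@H](C(=O)Nc4cccc(C(=O)O)c4)C3)[C@H](C)[C@H]12`: 45%
Compound 2 `C[C@@H](O)[C@H]1C(=O)N2C(C(=O)OCOC(=O)C(C)(C)C)=C(S[C@@H]3CN[C@H](C(=O)Nc4cccc(C(=O)OCOC(=O)C(C)(C)C)c4)C3)[C@H](C)[C@H]12`: 36%
Compound 3 `CC(=O)O[C@H](C)[C@H]1C(=O)N2C3=C(S[C@@H]4CN[C@@H](C4)C(=O)Nc4cccc(c4)C(=O)OCOCOC3=O)[C@H](C)[C@H]12`: 30%

In an ADME assay on a cell-free system (plasma, Homo sapiens) for metabolic stability, read by LC-MS, with a stated time of 60 min, at 37 degrees C, tested at 50 uM (a higher number here means that more of the compound is left, a lower number that less of the compound is left), compound 1 stands highest of the three numbers. Compound 2 comes nearest, with a number 9 percentage points lower from compound 1 to compound 2 (within the scatter). Compound 3 lies furthest, and the gap between compound 1 and compound 3 is beyond the scatter.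

Compound 4 `CC(C)C(=O)OCOC(=O)C1=C(S[C@@H]2CN[C@H](C(=O)Nc3cccc(C(=O)O)c3)C2)[C@H](C)[C@@H]2[C@@H]([C@@H](C)O)C(=O)N12` differs from compound 1 in a single place: hydrogen in place of methyl on a saturated chain carbon bound to a carbonyl carbon and two saturated chain carbons. Within the data shown here, the one measured step, from compound 1 to compound 2, concerns a different change and so does not bear directly on this one. Among the measured compounds shown here, with no measured step touching this kind of change, the expectation is a step of no more than the scatter, in either direction: a number 2 percentage points lower from compound 1 to compound 4 (within the scatter). Compound 4 is therefore estimated at 43%, within a range from 28% to 58%.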

Compound 4, percent of the compound remaining: 15%
Estimate against measurement, compound 4: 28 percentage points above; the measured number lies below the stated range.
By their numbers in this assay, from the lowest: compound 4; then compounds 3, 2 and 1 (each within the scatter of the next, the first and the last beyond it).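

Trimming tert-butyl to isopropyl, a change of a single methyl, gives a number 30 percentage points lower from compound 1 to compound 4 (beyond the scatter) in this assay. Among these compounds, this is the first step between compounds differing in one place that is printed as beyond the scatter, so this position responds strongly to a very small change. Nothing available here accounts for the drop. Still open, from the compounds shown here alone, is whether an ethyl or a cyclohexyl group in this place would stand nearer compound 1 or compound 4. Also open, going by these compounds, is whether a longer chain would change the number at all.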